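A few compounds are considered here, and "the series" means these few. Any claim that something is new, unique, unknown or untested is made for them only; others in the source may bear on it.

Among the measured compounds shown here, compound 1 `CC(C)Oc1cc(-c2cncc(-c3cnn(C4COC4)c3)c2)ccc1C(N)=O` is the stronger of the two compounds measured so far. In an assay on cells for inhibition of MAP kinase-interacting serine/threonine-protein kinase 1 (Homo sapiens), read by mobility shift assay, with stated times of 10 min and 60 min, in the presence of a further agent that is not named here (a lower number here means a stronger inhibitor, a higher number a weaker inhibitor), compound 1 gives 200 nM. For the measured compounds named here, the only other measured compound, compound 2 `NC(=O)c1ccc(-c2ccc(N)nc2)cc1`, gives 34000 nM in this assay, a much higher number that lies well beyond the usual scatter of repeated measurements, so compound 1 stands clearly apart from it.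

Compound 3 `CNC(=O)c1cncc(-c2ccc(C(N)=O)c(OC(C)C)c2)c1` has not yet been measured. It differs from compound 1 in one place: methylcarbamoyl in place of 1-(oxetan-3-yl)-1H-pyrazol-4-yl on an aromatic carbon. A ring-bearing group of nine heavy atoms is thus exchanged for a small open-chain group of four heavy atoms at the same position on the core.

Going by the values given here, with no measured pair that isolates this exchange, the expectation rests on the two values shown. The smaller compound 2 is far weaker than compound 1, which suggests that trimming compound 1 back toward a smaller molecule is more likely to raise the number than to lower it. The expected step is a 10-fold higher number from compound 1 to compound 3 (1.00 log units; beyond the scatter), a loss beyond the scatter. For compound 3 the estimate in this assay is 2000 nM, with a range from 400 nM to 10000 nM.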

Compound 3, half-maximal inhibitory concentration: 1900 nM
Compound 3: the middle estimate sits 1.1-fold (0.02 log units) above what was measured, within the range that was stated.
By their numbers in this assay, from the lowest: compound 1; then compound 3; then compound 2.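

In this assay, among the compounds shown here, the exchange of 1-(oxetan-3-yl)-1H-pyrazol-4-yl for methylcarbamoyl, on an aromatic carbon two atoms from the ring nitrogen, gives a 9.5-fold higher number from compound 1 to compound 3 (0.98 log units; beyond the scatter) and is the first single-place change that can be read here. It shows that this position is not indifferent to what sits on it: a loss beyond the usual scatter follows when the two-ring group gives way to a small open-chain group with no ring, yet compound 3 still returns a defined number in the assay. Nothing measured here explains why the number rises.

The exchange alters several things at once, including the rings, the heavy-atom count and the hydrogen-bond donors, so these compounds cannot show which of those differences accounts for the step. As far as these compounds go, it stays open whether a smaller ring group such as 1-methyl-1H-pyrazol-4-yl, or an open-chain group such as a carboxylic acid, at this same carbon would give a number closer to that of compound 1 or to that of compound 3.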